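Ester series: cytotoxicity limits and a dichlorophenyl replacement

The source may hold more compounds than are shown below. What is called first, only, known or untested is meant among the compounds shown, and "the series" means these compounds.

Measured so far:
- compound 1 `CC(C)N(Cc1cccc(OCCCCCC(=O)O)c1)C(=O)c1ccc(-c2ccco2)cc1`: > 26000 nM
- compound 2 `CC(C)N(Cc1cccc(OCCCCCC(=O)O)c1)C(=O)c1ccc(-c2c[nH]c3ccccc23)cc1`: > 26000 nM
- compound 3 `CCOC(=O)CCCCCOc1cccc(CN(C(=O)c2ccc(-c3ccco3)cc2)C(C)C)c1`: > 26000 nM

In an ADME assay on HepG2 cells (Homo sapiens) for cytotoxicity, read by CellTiter-Glo and resazurin assay, with a stated time of 72 h (a lower number here means that less compound is needed, a higher number that more compound is needed for the effect), compound 1 gives > 26000 nM, which is a limit of the assay and not a number. In this assay compound 2 gives > 26000 nM, again a limit. In this assay compound 3 gives > 26000 nM, also a limit. The step that the two limits leave unreadable from compound 1 to compound 2 and the step that the two limits leave unreadable from compound 1 to compound 3 therefore cannot be sized, and compound 3 stands at the same limit as the other two (the limit of > 26000 nM in this assay, at which 3 of the 3 values shown sit).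

Compound 4 `CCOC(=O)CCCCCOc1cccc(CN(C(=O)c2ccc(-c3ccc(Cl)c(Cl)c3)cc2)C(C)C)c1` is not yet measured. It differs from compound 3 by 3,4-dichlorophenyl in place of furan-2-yl on an aromatic carbon.

Neither measured step bears readably on this change, since both end at the limit. No step beyond the scatter can be predicted; the most likely outcome in this assay is again a limit. The step that the limit leaves unreadable from compound 3 to compound 4 is the expected change. For compound 4 the estimate in this assay is 30000 nM, ranging from 10000 nM to 100000 nM.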

Compound 4, half-maximal effective concentration: > 26000 nM
Compound 4: a limit, no number; the forecaster's own chance of this, stated with the estimate: 75%; the middle value does not contradict the limit.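

No step can be read between compound 3 and compound 4, since both values are limits and not numbers: the limit of > 26000 nM in this assay, at which 4 of the 4 values shown sit.

The compounds shown leave open whether any change in this series gives a value inside the readable range, and so a step of measurable size.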